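One change, tested on a second core

The source may report more compounds than this note shows. Statements on the series, on what has been measured and on what is new or still open speak of the compounds shown alone.

Compound 1 `COc1cc2c(Oc3ccc(NC(=O)c4cn(-c5c(C)cccc5C)nn4)cc3F)ccnc2cc1OCCCN1CCC(C)CC1` and compound 3 `COc1cc2c(Oc3ccc(NC(=O)c4cn(-c5c(C)cccc5C)nn4)cc3F)ccnc2cc1OCCCN1CCN(C)CC1` share most of their structure. In a functional assay on A549 cells (Homo sapiens) for cytotoxicity, read by MTT assay, with a stated time of 72 h (a lower number here means a stronger inhibitor, a higher number a weaker inhibitor), compound 1 gives 3340 nM, and compound 3 gives 2180 nM. Their cores differ in one group: 4-methylpiperazin-1-yl in place of 4-methylpiperidin-1-yl on a saturated chain carbon, three bonds along the chain from an oxygen on an aromatic ring. That difference made a 1.5-fold lower number from compound 1 to compound 3 (0.19 log units; within the scatter). Compound 2 `COc1cc2c(Oc3ccc(NC(=O)c4cn(-c5ccc(F)c(F)c5)nn4)cc3F)ccnc2cc1OCCCN1CCC(C)CC1` is compound 1 with one group exchanged: 3,4-difluorophenyl in place of 2,6-dimethylphenyl on an aromatic nitrogen. In this assay compound 2 gives 1460 nM, so the exchange made a 2.3-fold lower number from compound 1 to compound 2 (0.36 log units; beyond the scatter). Compound 4 `COc1cc2c(Oc3ccc(NC(=O)c4cn(-c5ccc(F)c(F)c5)nn4)cc3F)ccnc2cc1OCCCN1CCN(C)CC1` has not yet been measured; it stands to compound 3 as compound 2 stands to compound 1, carrying (3,4-difluorophenyl in place of 2,6-dimethylphenyl on an aromatic nitrogen), which is the same change made on the other core. The expected step in this assay is a 2.2-fold lower number from compound 3 to compound 4 (0.34 log units; beyond the scatter), since the same change on the first core made a 2.3-fold lower number from compound 1 to compound 2 (0.36 log units; beyond the scatter). This rests on one earlier pairing only, and the two cores themselves sit close together, so the expectation is a loose one. For compound 4 the estimated value in this assay is 1000 nM, expected to fall between 500 nM and 2000 nM.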

Compound 4, half-maximal inhibitory concentration: 200 nM
For compound 4 the middle estimate is 5.0-fold (0.70 log units) above the measured one; the whole stated range lies above it.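

On the core of compound 3, 3,4-difluorophenyl in place of 2,6-dimethylphenyl gave an 11-fold lower number from compound 3 to compound 4 (1.04 log units; beyond the scatter) in this assay and so did far more than on the core of compound 1: the same change on two cores in this assay, a 2.3-fold lower number (0.36 log units; beyond the scatter) from compound 1 to compound 2 and an 11-fold lower number (1.04 log units; beyond the scatter) from compound 3 to compound 4, 4.8-fold (0.68 log units) apart, beyond the scatter of two such steps.

Read the other way, 4-methylpiperazin-1-yl in place of 4-methylpiperidin-1-yl gave a 7.3-fold lower number from compound 2 to compound 4 (0.86 log units; beyond the scatter) when 3,4-difluorophenyl was present, yet only a step within the scatter when 2,6-dimethylphenyl was present: the same change on two cores in this assay, a 1.5-fold lower number (0.19 log units; within the scatter) from compound 1 to compound 3 and a 7.3-fold lower number (0.86 log units; beyond the scatter) from compound 2 to compound 4, 4.8-fold (0.68 log units) apart, beyond the scatter of two such steps.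

Across these four compounds, then, the size of each step depends on the group at the other place, so a step seen on one core did not predict its size on the other; this single set does not show why, or whether other pairs of groups would behave the same way.

Still open, on these data alone, is whether both fluorines are needed, which a 4-fluorophenyl or a 3-fluorophenyl group could test. Also open, as far as these compounds go, is whether the large step is tied to the 4-methylpiperazin-1-yl group or would also appear with a morpholin-4-yl group at the end of the chain.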